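A few compounds are considered here, and "the series" means these few. Any claim that something is new, unique, unknown or untested is made for them only; others in the source may bear on it.

Compound 1 `Cc1ccccc1Nc1nc(Nc2cccnc2)ncc1Cl` gives 38600 nM
Compound 2 `Cc1ccccc1Nc1nc(Nc2ccccn2)ncc1Cl` gives 20100 nM
Compound 3 `Cc1ccccc1Nc1nc(Nc2ccc(N3CCN(C)CC3)cn2)ncc1Cl` gives 8080 nM

In a functional assay on Jurkat cells (Homo sapiens) for inhibition, read by CCK-8 assay, with a stated time of 48 h (a lower number here means a stronger inhibitor of growth, a higher number a weaker inhibitor of growth), compound 3 stands lowest of the three, with compound 2 nearest (compound 2 at 20100 nM) and compound 1 furthest (compound 1 at 38600 nM). Compound 4 `CCN1CCN(c2ccc(Nc3ncc(Cl)c(Nc4ccccc4C)n3)nc2)CC1` carries a single change from compound 3 (methyl in place of hydrogen on a saturated chain carbon bound to an amine nitrogen in a ring): methyl in place of hydrogen on a saturated chain carbon bound to an amine nitrogen in a ring, which turns 4-methylpiperazin-1-yl into 4-ethylpiperazin-1-yl. Among the measured compounds shown here, no measured pair tests this exact change. The step that bears most on it is the one that brought in 4-methylpiperazin-1-yl (a 2.5-fold lower number from compound 2 to compound 3 (0.40 log units; beyond the scatter)), and on that modest size the added methyl is expected to give no step beyond the scatter in this assay in either direction. The other step (a 1.9-fold lower number from compound 1 to compound 2 (0.28 log units; within the scatter)) concerns a different part of the structure, pyridin-2-yl in place of pyridin-3-yl, and says little here. The expected step is small (a 1.1-fold lower number from compound 3 to compound 4 (0.03 log units; within the scatter)) and this estimate stays within the scatter. Compound 4 is estimated at 7500 nM (expected range 3500 nM to 16000 nM).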

Compound 4, concentration for 50% growth inhibition: > 100000 nM
Compound 4 was reported as a limit; the forecaster's own chance of this, stated with the estimate: 3%; at least 13-fold (1.12 log units) between middle value and limit.
By their numbers in this assay, from the lowest: compound 3; then compounds 2 and 1 (each within the scatter of the next). At a limit, above all of these: compound 4.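

In this assay, compound 4 is reported as a limit and not as a number: the limit of > 100000 nM in this assay, at which 1 of the 4 values shown sits.

The earlier compounds shown here showed this position only as the place where 4-methylpiperazin-1-yl entered, and they gave no sign of how it would respond to a further change in that group. Here a single methyl, placed on a saturated chain carbon bound to an amine nitrogen in a ring, turns 4-methylpiperazin-1-yl into 4-ethylpiperazin-1-yl and gives a large step (an at least 12-fold higher number from compound 3 to compound 4 (1.09 log units; beyond the scatter)), so the outcome at this position depends strongly on one added carbon. Measured against hydrogen on the aromatic carbon, the two groups also point in opposite directions, with 4-methylpiperazin-1-yl giving (a 2.5-fold lower number from compound 2 to compound 3 (0.40 log units; beyond the scatter)) and 4-ethylpiperazin-1-yl giving (an at least 4.9-fold higher number from compound 2 to compound 4 (0.69 log units; beyond the scatter)).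

The compounds shown leave open how a piperazin-1-yl group with a free amine hydrogen, a longer chain such as propyl, or a 2-hydroxyethyl group on that same ring nitrogen would read in this series. They also leave open whether methyl to ethyl would act in the same way with pyridin-3-yl in place of pyridin-2-yl.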